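A few compounds are considered here, and "the series" means these few. Any claim that something is new, unique, unknown or untested is made for them only; others in the source may bear on it.

The series was tested in a functional assay on HepG2 cells (Homo sapiens) for cytotoxicity, read by MTT assay, with a stated time of 48 h; on this read-out higher numbers stand for weaker inhibition and lower numbers for stronger inhibition. Compound 1 `COc1cc(-c2nnc3n2NC(c2ccco2)C(C(=O)c2ccc(F)c(F)c2)S3)cc(OC)c1OC` gives 52400 nM there, and compound 3 `COc1ccc(C(=O)C2Sc3nnc(-c4cc(OC)c(OC)c(OC)c4)n3NC2c2cccs2)cc1` gives 68000 nM. Compound 2 `COc1cc(-c2nnc3n2NC(c2ccco2)C(C(=O)c2cccc(Br)c2)S3)cc(OC)c1OC` reaches only the limit of the assay, > 100000 nM, and not a number. Among the measured compounds shown here, the one measured step to compound 2, an at least 1.9-fold higher number from compound 1 to compound 2 (0.28 log units; that floor lies within the scatter), is thus itself only a floor, and that floor lies within the scatter; this reading rests on (the limit of > 100000 nM in this assay, at which 1 of the 3 values shown sits). The unmeasured compound 4 `COc1cc(-c2nnc3n2NC(c2ccco2)C(C(=O)c2ccccc2C)S3)cc(OC)c1OC` differs from compound 2 by 2-methylphenyl in place of 3-bromophenyl on a carbonyl carbon. For the measured compounds named here, no measured step in this set exchanges 3-bromophenyl for 2-methylphenyl on the carbonyl carbon; the nearest comparison, the step from compound 1 to compound 2, also sits on a carbonyl carbon but runs from 3,4-difluorophenyl to 3-bromophenyl, and it stayed within the scatter. All known numbers in this assay are high and lie close to one another, which gives no ground for a shift in either direction. The step from compound 2 to compound 4 in this assay is therefore expected to be an at least 1.1-fold lower number from compound 2 to compound 4 (0.04 log units; that floor lies within the scatter), not beyond the scatter. Compound 4 is estimated at 90000 nM in this assay, within a range from 40000 nM to 200000 nM, with a real chance that only a limit is reported again.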

Compound 4, half-maximal inhibitory concentration: 63000 nM
Estimate against measurement, compound 4: 1.4-fold (0.15 log units) above, within the range that was stated.
By their numbers in this assay, from the lowest: compounds 1, 4 and 3 (each within the scatter of the next). At a limit, above all of these: compound 2.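

In this assay compound 2 stays at a limit of the assay and not a number, > 100000 nM. Among the compounds shown here, with 2-methylphenyl in place of 3-bromophenyl on the carbonyl carbon, this position now gives a number, and the change reads as an at least 1.5-fold lower number from compound 2 to compound 4 (0.20 log units; that floor lies within the scatter), which fixes only one side of the step and does not carry it beyond the scatter; that reading rests on a limit: the limit of > 100000 nM in this assay, at which 1 of the 4 values shown sits. Against compound 1, the first step at this position with numbers at both ends is a 1.2-fold higher number from compound 1 to compound 4 (0.08 log units; within the scatter), so 2-methylphenyl and 3,4-difluorophenyl on this carbonyl carbon cannot be told apart in this read-out.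

As far as these compounds go, the true size of the step between the 3-bromophenyl and 2-methylphenyl groups stays open, since one end of it is a limit, and with it the question of whether this change has any real effect on the number. The compounds shown also leave open whether a group of a different kind on this carbonyl carbon, such as a carboxylic acid on the phenyl ring, an amine or a longer chain, would move the number beyond the scatter in either direction.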